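Swapping the Amide Phenyl for a Butyl Chain

The compounds below may be only part of what the source reports. "The series", "measured", "known", "first", "only" and "open" are said of these compounds alone.

Measured compounds:
Compound 1, `Nc1sc(-c2ccc(Cl)cc2)c(-c2ccc(Cl)cc2)c1C(=O)NCc1ccccc1`: 16300 nM
Compound 2, `Nc1sc(-c2ccc(Cl)cc2)c(-c2ccc(Cl)cc2)c1C(=O)Nc1ccccc1`: 25000 nM

Both compounds were tested in a functional assay on A549 cells (Homo sapiens) for inhibition, read by sulforhodamine B assay, with a stated time of 72 h; a higher number here means a weaker inhibitor, a lower number a stronger inhibitor. Compound 2 gives 25000 nM, the higher of the two numbers, while compound 1 gives 16300 nM; the step of a 1.5-fold higher number from compound 1 to compound 2 (0.19 log units; within the scatter) is within the scatter, so the two cannot be told apart.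

Compound 3, `CCCCNC(=O)c1c(N)sc(-c2ccc(Cl)cc2)c1-c1ccc(Cl)cc1`, differs from compound 2 by butyl in place of phenyl on an amide-type nitrogen. Among the measured compounds shown here, the only measured step touches the same amide nitrogen, a 1.5-fold higher number from compound 1 to compound 2 (0.19 log units; within the scatter), and it stayed within the scatter. For the measured compounds named here, no measured pair exchanges phenyl for butyl, so there is no direct guide to that change. Going by the values given here, with one small step at this position as the only evidence, compound 3 is expected to show no step beyond the scatter, a 1.3-fold lower number from compound 2 to compound 3 (0.10 log units; within the scatter).

Compound 3 is therefore estimated at 20000 nM, with a likely range from 8000 nM to 50000 nM.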

Compound 3, half-maximal inhibitory concentration: 8170 nM
The estimate for compound 3 lay 2.4-fold (0.39 log units) above the measured number; low and high end bracket the measured number.
By their numbers in this assay, from the lowest: compounds 3, 1 and 2 (each within the scatter of the next, the first and the last beyond it).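

In this assay, among the compounds shown here, butyl on the amide-type nitrogen gives the first step at this position that lies beyond the scatter, a 3.1-fold lower number from compound 2 to compound 3 (0.49 log units; beyond the scatter) and a modest one. Compared with the benzyl group, the picture differs: the step of a 2.0-fold lower number from compound 1 to compound 3 (0.30 log units; within the scatter) stays within the scatter, so compound 3 and compound 1 cannot be told apart, even though the butyl chain has no ring. The result therefore shows that an aromatic ring on this nitrogen is not needed to keep the activity seen here, but nothing measured explains the step.

The compounds shown leave open whether a longer chain such as hexyl would go further in the same direction. They also leave open how a butyl chain ending in an amine or a carboxylic acid would behave at this nitrogen.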